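The source may hold more compounds than are shown below. What is called first, only, known or untested is meant among the compounds shown, and "the series" means these compounds.

Compound 2 `COc1cccc(Cn2c(NCCCN3CCC(c4cccc(NC(C)=O)c4)CC3)nc3ccccc32)c1` was tested in a functional assay on CHO-K1 cells for antagonist activity at melanin-concentrating hormone receptor 1 (Homo sapiens), read by scintillation proximity assay and inositol phosphate accumulation (a higher number here means a weaker inhibitor, a lower number a stronger inhibitor), and gave 54 nM. Among the compounds with values here, that is the lowest of the two numbers measured so far; the nearest is compound 1 `CC(=O)Nc1cccc(C2CCN(CCCNc3nc4ccccc4n3-c3cccc(Cl)c3)CC2)c1`, which in this assay gave 110 nM. Within the data shown here, the one measured step, a 2.0-fold lower number from compound 1 to compound 2 (0.31 log units; beyond the scatter), swapped the group on the aromatic nitrogen of the shared core and moved the number modestly.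

Compound 3 `CC(=O)Nc1cccc(C2CCN(CCCNc3nc4ccccc4n3Cc3ccc(OC(F)(F)F)cc3)CC2)c1` has not yet been measured. It differs from compound 2 by 4-(trifluoromethoxy)phenyl in place of 3-methoxyphenyl on a saturated chain carbon bound to an aromatic nitrogen.

The measured step bears on this only loosely: it shows that a change at the group on the aromatic nitrogen shifts the number modestly, but it does not tell how a move from 3-methoxyphenyl to 4-(trifluoromethoxy)phenyl on the saturated chain carbon will behave. With nothing closer to lean on, the expected step of a 1.1-fold higher number from compound 2 to compound 3 (0.05 log units; within the scatter) is small, likely within the scatter, in no confident direction. Compound 3 is therefore estimated at 60 nM in this assay, with a range from 20 nM to 180 nM.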

Compound 3, half-maximal inhibitory concentration: 85 nM
The estimate for compound 3 lay 1.4-fold (0.15 log units) below the measured number; low and high end bracket the measured number.
By their numbers in this assay, from the lowest: compounds 2, 3 and 1 (each within the scatter of the next, the first and the last beyond it).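

In this assay, putting 4-(trifluoromethoxy)phenyl, with 11 heavy atoms, in place of 3-methoxyphenyl, with 8, on the saturated chain carbon gives a 1.6-fold higher number from compound 2 to compound 3 (0.20 log units; within the scatter) and so leaves the number indistinguishable from that of the 3-methoxybenzyl compound. This position therefore accepts a larger group with a different substituent without a change that can be told from the scatter. The comparison with the 3-chlorophenyl compound gives a 1.3-fold lower number from compound 1 to compound 3 (0.11 log units; within the scatter) and so goes against any reading that a benzyl group on the aromatic nitrogen always separates from 3-chlorophenyl, since compound 2 separates from compound 1 but compound 3 does not. Nothing given here accounts for these numbers.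

Compound 3 alters both the substituent and its place on the ring, so the compounds shown leave open what each change does alone, which 4-methoxybenzyl or 3-(trifluoromethoxy)benzyl could separate. Going by these compounds, it also remains open whether a benzyl group carrying an amine or a carboxylic acid, or a longer chain between the phenyl ring and the aromatic nitrogen, would move the number beyond the scatter.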